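Compound 4 Against Compound 2: An Expected Weaker Effect

The source may hold more compounds than are shown below. What is called first, only, known or untested is meant among the compounds shown, and "the series" means these compounds.

Compound 1 `O=C(Nc1cccc(-n2cc(-c3ccncc3)c(-c3cc(O)cc(Cl)c3)n2)c1)Nc1ccc(Cl)c(C(F)(F)F)c1` gives 5.22% in a functional assay on MDA-MB-468 cells (Homo sapiens) for inhibition, read by sulforhodamine B assay, with a stated time of 48 h, tested at 10 uM; a lower number here means a stronger effect, a higher number a weaker effect of the compound at the concentration tested. Compound 2 `COc1cc(Cl)cc(-c2nn(-c3cccc(NC(=O)Nc4ccc(Cl)c(C(F)(F)F)c4)c3)cc2-c2ccncc2)c1` gives -14.4% in this assay, the lowest of the three numbers, while compound 3 `COc1cc(Cl)cc(-c2nn(-c3cccc(NC(=O)Nc4cc(C(F)(F)F)cc(C(F)(F)F)c4)c3)cc2-c2ccncc2)c1` gives -2.95%. Among the measured compounds shown here, the only single-point step measured is a number 19.6 percentage points lower from compound 1 to compound 2 (beyond the scatter). Compound 4 `COc1cc(Cl)cc(-c2nn(-c3cccc(NC(=O)c4cccc(C(F)(F)F)c4)c3)cc2-c2ccncc2)c1` differs from compound 2 in one place: 3-(trifluoromethyl)phenyl in place of (4-chloro-3-(trifluoromethyl)phenyl)amino on a carbonyl carbon. For the measured compounds named here, no measured step covers this change; the step from compound 1 to compound 2 concerns a different position, and compound 3 shows only that a change on the same part of the molecule gives a higher number than compound 2. Compound 4 is therefore expected to give a higher number, a step of a number 19.4 percentage points higher from compound 2 to compound 4 (beyond the scatter), with an estimate of 5% and a range from -15% to 30%.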

Compound 4, a percentage reported as activity, at one concentration (the size of the read-out at that concentration, not a potency): 47%
Compound 4: the middle estimate sits 42 percentage points below what was measured, outside the stated range (above it).
By their numbers in this assay, from the lowest: compound 2; then compounds 3 and 1 (each within the scatter of the next); then compound 4.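

In this assay, among the compounds shown here, putting 3-(trifluoromethyl)phenyl in place of (4-chloro-3-(trifluoromethyl)phenyl)amino on a carbonyl carbon gives a number 61.4 percentage points higher from compound 2 to compound 4 (beyond the scatter), so this position, unlike what the earlier compounds showed, can carry a large loss of effect at the concentration tested. The change takes away the amino nitrogen, with its hydrogen-bond donor, and the chlorine together. No measurement available here explains the step. The compounds shown leave open whether the nitrogen or the chlorine accounts for it. A 4-chloro-3-(trifluoromethyl)phenyl group or a (3-(trifluoromethyl)phenyl)amino group on that carbonyl carbon would separate the two.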